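Chloro addition in two cores: a cytotoxicity estimate

A few compounds are considered here, and "the series" means these few. Any claim that something is new, unique, unknown or untested is made for them only; others in the source may bear on it.

Measured compounds in an ADME assay on HS27 cells (Homo sapiens) for cytotoxicity, read by MTT assay; on this read-out higher numbers stand for weaker inhibition and lower numbers for stronger inhibition:
compound 1 `O=C(Nc1ccc(-n2ccc3nc(C(=O)NCc4ccccc4)ccc32)cc1)Nc1ccc(Cl)c(C(F)(F)F)c1`, compound 1 gives 3000 nM.
compound 2 `COC(=O)c1ccc2c(ccn2-c2cccc(NC(=O)Nc3cccc(C(F)(F)F)c3)c2)n1`, compound 2 gives > 10000 nM, a limit of the assay.
compound 3 `O=C(Nc1ccc(-n2ccc3nc(C(=O)NCc4ccccc4)ccc32)cc1)Nc1cccc(C(F)(F)F)c1`, compound 3 gives > 10000 nM, a limit of the assay.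

Compound 1 and compound 3 share a core and differ by chloro in place of hydrogen on an aromatic carbon. This change made an at least 3.3-fold lower number from compound 3 to compound 1 (0.52 log units; beyond the scatter). Compound 2 carries a different core; how it differs from compound 3 is not broken down here. Compound 4 `COC(=O)c1ccc2c(ccn2-c2cccc(NC(=O)Nc3ccc(Cl)c(C(F)(F)F)c3)c2)n1`, not yet measured, differs from compound 2 by chloro in place of hydrogen on an aromatic carbon, the same change as from compound 3 to compound 1, at a place described in the same words. Because (the limit of > 10000 nM in this assay, at which 2 of the 3 values shown sit), the measured step is known only as a lower bound. Compound 4 is expected to show an at least 2.5-fold lower number from compound 2 to compound 4 (0.39 log units; beyond the scatter), resting on the step of an at least 3.3-fold lower number from compound 3 to compound 1 (0.52 log units; beyond the scatter) seen with the same change. Compound 4 is estimated at 4000 nM, between 1500 nM and 15000 nM.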

Compound 4, half-maximal inhibitory concentration: > 10000 nM
Compound 4: a limit, no number (the forecaster's own chance of this, stated with the estimate: 40%); at least 2.5-fold (0.39 log units) between middle value and limit.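

In this assay, within the data shown here, no step from compound 2 to compound 4 can be read, because both compounds sit at a limit of the assay: the limit of > 10000 nM in this assay, at which 3 of the 4 values shown sit. Going by these compounds, whether chloro in place of hydrogen lowers the number with the core of compound 2, as it does with the core of compound 1, stays open.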